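The compounds below may be only part of what the source reports. "The series", "measured", "known", "first", "only" and "open" are said of these compounds alone.

Compound 3 `COc1ccc2ccc(=O)oc2c1C(/C=C/c1ccc(C)cc1)=N/NC(N)=O` is one of three close relatives that share a core and differ in a single group. In a functional assay on HepG2 cells (Homo sapiens) for cytotoxicity, read by MTT assay, with a stated time of 72 h (a higher number here means a weaker inhibitor, a lower number a stronger inhibitor), compound 3 gives 93 nM. Compound 1 `COc1ccc2ccc(=O)oc2c1C(/C=C/c1ccc(C(F)(F)F)cc1)=N/NC(N)=O` gives 96 nM in this assay, and compound 2 `COc1ccc2ccc(=O)oc2c1C(/C=C/c1ccc(SC)cc1)=N/NC(N)=O` gives 99 nM. Compound 3 thus stands level with the other two; none can be called stronger or weaker. The steps among them are all flat: a 1.0-fold higher number from compound 1 to compound 2 (0.01 log units; within the scatter), a 1.0-fold lower number from compound 1 to compound 3 (0.01 log units; within the scatter) and a 1.1-fold lower number from compound 2 to compound 3 (0.03 log units; within the scatter). Compound 4 `COc1ccc2ccc(=O)oc2c1C(/C=C/c1cccs1)=N/NC(N)=O` brings a different kind of change: thiophen-2-yl in place of 4-methylphenyl on a double-bonded chain carbon bound to a double-bonded chain carbon. Within the data shown here, no measured step swaps one ring for another, so the three flat steps bear on it only loosely, showing that this end of the molecule has so far made no difference. A flat step is therefore expected, a 1.1-fold higher number from compound 3 to compound 4 (0.03 log units; within the scatter), with wider uncertainty. Compound 4 is estimated at 100 nM, between 45 nM and 220 nM.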

Compound 4, half-maximal inhibitory concentration: 75 nM
The estimate for compound 4 lay 1.3-fold (0.12 log units) above the measured number, and the stated range covers the measured number.
By their numbers in this assay, from the lowest: compounds 4, 3, 1 and 2 (each within the scatter of the next).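

Earlier steps only exchanged the group carried on a six-membered aromatic ring of carbon, whereas compound 4 replaces that whole ring with thiophen-2-yl. In this assay the numbers still read level, with a 1.2-fold lower number from compound 3 to compound 4 (0.09 log units; within the scatter) and a 1.3-fold lower number from compound 2 to compound 4 (0.12 log units; within the scatter) and also a 1.3-fold lower number from compound 1 to compound 4 (0.11 log units; within the scatter), so at this place a five-membered aromatic ring with a sulfur atom matches the three substituted phenyl groups. Nothing available accounts for this level reading. As far as these compounds go, whether an amine, a carboxylic acid or a saturated ring such as cyclohexyl at this place would also read level stays open.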